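Swapping tert-butyl for cyclopentenyl on a weak aortic inhibitor

The source may report more compounds than this note shows. Statements on the series, on what has been measured and on what is new or still open speak of the compounds shown alone.

Measured compounds:
compound 1 `Nc1ccnc(-c2nn(Cc3ccccc3F)c3ncccc23)n1` in a functional assay (aorta) with Oryctolagus cuniculus as the target; a higher number here means a weaker inhibitor, a lower number a stronger inhibitor: 270 nM; 265000 nM (2 entries)
compound 2 `CC(C)(C)c1cnc(-c2nn(Cc3ccccc3F)c3ncccc23)nc1N` in this assay: 709000 nM

Compound 1 is recorded more than once in this assay, and its entries lie far apart (the several entries of compound 1 in this assay, 270 nM; 265000 nM (2 entries)). Compound 2 has a single number, which is the highest value shown, so it counts as the weaker inhibitor among the numbers given. Compound 3 `Nc1nc(-c2nn(Cc3ccccc3F)c3ncccc23)ncc1C1=CCCC1` has not yet been measured. It differs from compound 2 in one place: cyclopent-1-en-1-yl in place of tert-butyl on an aromatic carbon. Within the data shown here, no step between two measured compounds covers such an exchange, so there is no direct guide to its size. The exchange keeps the group small and free of donors and acceptors, so only a modest shift is expected, in either direction, with a slight lean toward a lower value, and the expected step is a 2.0-fold lower number from compound 2 to compound 3 (0.31 log units; beyond the scatter). Compound 3 is therefore estimated at 350000 nM, with a range from 40000 nM to 3000000 nM.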

Compound 3, half-maximal inhibitory concentration: 836000 nM
The estimate for compound 3 lay 2.4-fold (0.38 log units) below the measured number, within the range that was stated.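

In this assay, cyclopent-1-en-1-yl in place of tert-butyl gives a 1.2-fold higher number from compound 2 to compound 3 (0.07 log units; within the scatter) and so leaves the two compounds indistinguishable. This is the only direct reading shown for a change at this position, on the aromatic carbon ortho to an amino group. It shows that, for this pair, an open tert-butyl can give way to a five-membered ring of carbon only, with a double bond, without a step beyond the scatter.

Going by these compounds, whether an amine or a carboxylic acid at this position would move the number stays open, since both groups compared here are made of carbon only with no hydrogen-bond donors or acceptors. On these data alone, what any group at this position contributes also stays open, as compound 1 gives no single number to compare with: the several entries of compound 1 in this assay, 270 nM; 265000 nM (2 entries).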